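A few compounds are considered here, and "the series" means these few. Any claim that something is new, unique, unknown or untested is made for them only; others in the source may bear on it.

Compound 1, `COc1ccc(OCC2=NCCO2)cc1`, is one of three compounds tested in a toxicity assay on the whole organism with Rattus norvegicus as the target, at a dose of 100 mg/kg by the oral route; a higher number here means a stronger effect of the compound at the dose given, a lower number a weaker effect. Compound 1 gives 50%, the second highest of the three numbers. Its nearest neighbour is compound 3, `Cc1ccccc1OCC1=NCCO1`, which gives 40%, within the scatter of compound 1. Furthest from it is compound 2, `Brc1ccccc1OCC1=NCCO1`, which gives 70%, beyond the scatter above compound 1 and the highest number of the three. The unmeasured compound 4, `Brc1ccc(OCC2=NCCO2)cc1`, differs from compound 1 by bromo in place of methoxy on an aromatic carbon. Within the data shown here, only one measured step bears on this change: a number 30 percentage points lower from compound 2 to compound 3 (beyond the scatter), in which methyl took the place of bromo. Among the measured compounds shown here, no measured step exchanges methoxy for bromo, so the bearing is indirect; still, the compound carrying bromo, compound 2, stands highest, beyond the scatter above both others. A modest rise is therefore expected for compound 4. Compound 4 is estimated at 60%, with a range from 45% to 75%. This estimate corresponds to an expected a number 10 percentage points higher from compound 1 to compound 4 (within the scatter).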

Compound 4, a percentage reported as activity, at one dose (the size of the read-out at that dose, not a potency): 60%
Beside the measured number, compound 4's estimate shows no gap at the digits printed, and the stated range covers the measured number.
By their numbers in this assay, from the lowest: compounds 3, 1, 4 and 2 (each within the scatter of the next, the first and the last beyond it).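

Among these compounds, at the aromatic carbon para to a group of 7 heavy atoms, the first measured exchange on this position gives a number 10 percentage points higher from compound 1 to compound 4 (within the scatter), so in this assay bromo and methoxy are not told apart here, even though bromo enters with one heavy atom where methoxy leaves with two and loses a hydrogen-bond acceptor. The earlier step, a number 30 percentage points lower from compound 2 to compound 3 (beyond the scatter), is a different exchange, and it is the only one of the two that passes beyond the scatter, so a step beyond the scatter does not follow from bromo being involved in the change. Nothing measured on these groups accompanies the result, and it stands without an explanation.

The compounds shown leave open what an amine or a carboxylic acid on this aromatic carbon would give in this assay. They also leave open whether a longer chain such as butoxy in place of methoxy would move the number beyond the scatter.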